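A Fluoro Swap in a Level Series

A few compounds are considered here, and "the series" means these few. Any claim that something is new, unique, unknown or untested is made for them only; others in the source may bear on it.

Of the compounds shown here, three sharing one core have been measured in a functional assay on A549 cells (Homo sapiens) for antiproliferative activity, read by MTT assay, with a stated time of 48 h; on this read-out lower numbers stand for stronger inhibition and higher numbers for weaker inhibition. Compound 1 `CCCCOc1ccc(C(=O)/C=C/c2c(/C=C/c3ccc(OC)cc3)cc(OC)cc2OC)cc1` gives 8.7 ug/mL, compound 2 `CCCCCCOc1ccc(C(=O)/C=C/c2c(/C=C/c3ccc(OC)cc3)cc(OC)cc2OC)cc1` gives 8.4 ug/mL and compound 3 `COc1ccc(/C=C/c2cc(OC)cc(OC)c2/C=C/C(=O)c2ccc(C(F)(F)F)cc2)cc1` gives 7.8 ug/mL. Compound 3 thus stands level with the other two, and its steps to both lie within the scatter.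

Compound 4 `COc1ccc(/C=C/c2cc(OC)cc(OC)c2/C=C/C(=O)c2ccc(F)cc2)cc1` has not yet been measured in this assay. It differs from compound 3 in one place: fluoro in place of trifluoromethyl on an aromatic carbon. In words, the 4-(trifluoromethyl)phenyl of compound 3 becomes 4-fluorophenyl in compound 4.

For the measured compounds named here, two measured steps touch this same place. They are a 1.1-fold lower number from compound 1 to compound 3 (0.05 log units; within the scatter) and a 1.1-fold lower number from compound 2 to compound 3 (0.03 log units; within the scatter), and neither leaves the scatter. The step of a 1.0-fold lower number from compound 1 to compound 2 (0.02 log units; within the scatter), which lengthens the chain on that group, also stays within it. Going by the values given here, no measured compound carries fluoro, so the change itself remains untested. Three quite different groups at this place have so far given values within the scatter of one another. Compound 3 gives 7.8 ug/mL, and the step to compound 4 is expected to stay within the scatter. The estimated step is a 1.0-fold higher number from compound 3 to compound 4 (0.01 log units; within the scatter). Compound 4 is expected at 8 ug/mL, with an estimated range from 4.5 ug/mL to 14 ug/mL.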

Compound 4, half-maximal inhibitory concentration: 6.6 ug/mL
For compound 4 the middle estimate is 1.2-fold (0.08 log units) above the measured one; measured number inside the range.
By their numbers in this assay, from the lowest: compounds 4, 3, 2 and 1 (each within the scatter of the next).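

In this assay, fluoro now joins trifluoromethyl, butoxy and hexyloxy as a fourth group measured on this aromatic carbon, and the series remains level, with a 1.2-fold lower number from compound 3 to compound 4 (0.07 log units; within the scatter) and with a 1.3-fold lower number from compound 2 to compound 4 (0.10 log units; within the scatter) and a 1.3-fold lower number from compound 1 to compound 4 (0.12 log units; within the scatter) as well. The earlier compounds showed this only for groups of several heavy atoms, whereas compound 4 extends it to a single fluorine atom, so that, among these four compounds, neither the trifluoromethyl carbon nor a butoxy or hexyloxy chain is needed at this place to keep the value where it stands. The data offer no measured explanation for why these four groups give values within the scatter of one another.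

The compounds shown leave open whether this place would stay level with a group of a different kind, such as an amine or a carboxylic acid, or with plain hydrogen. They also leave open whether the value would move if a change were made elsewhere, for instance at the methoxy groups on the shared core, since all four compounds keep these unchanged.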